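One Substituent Swap Carried Across Two Different Cores

The compounds below may be only part of what the source reports. "The series", "measured", "known", "first", "only" and "open" are said of these compounds alone.

Compound 1 `CCOC(=O)c1onc(-c2cn(-c3ccccc3)nc2-c2ccc(Br)cc2)c1C(=O)OCC` gives 56.9% in a functional assay on the whole organism (Abdomen, strain Swiss albino) with Mus musculus as the target, with stated times of 10 min and 5 min, at a dose of 30 mg/kg by the oral route; on this read-out higher numbers stand for a stronger effect at the one dose given and lower numbers for a weaker effect.
Compound 2 `CCOC(=O)c1onc(-c2cn(-c3ccccc3)nc2-c2ccc(OC)cc2)c1C(=O)OCC` gives 57.7% in this assay.
Compound 3 `Brc1ccc(-c2nn(-c3ccccc3)cc2-c2cc(-c3ccccc3)on2)cc1` gives 31.4% in this assay.

From compound 1 to compound 2 the change is methoxy in place of bromo on an aromatic carbon, and in this assay it made a number 0.8 percentage points higher from compound 1 to compound 2 (within the scatter). Compound 3 stands lowest of the three, and its gaps to compound 1 and to compound 2 are both beyond the scatter; how the core of compound 3 differs from the core of compound 1 is not broken down here. Compound 4 `COc1ccc(-c2nn(-c3ccccc3)cc2-c2cc(-c3ccccc3)on2)cc1` carries the same change relative to compound 3, (methoxy in place of bromo on an aromatic carbon), at a place described in the same words. Among the measured compounds shown here, the single earlier instance rests on one pair only, so the expectation is loose. Compound 4 is expected to move by a number 1.6 percentage points higher from compound 3 to compound 4 (within the scatter) in this assay, because a number 0.8 percentage points higher from compound 1 to compound 2 (within the scatter) stayed within the scatter. Compound 4 is therefore estimated at 33%, between 20% and 48%.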

Compound 4, a percentage reported as activity, at one dose (the size of the read-out at that dose, not a potency): 31%
Estimate against measurement, compound 4: 2 percentage points above; measured number inside the range.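

In this assay, methoxy in place of bromo on an aromatic carbon made a number 0.4 percentage points lower from compound 3 to compound 4 (within the scatter). Set beside the earlier pair, the change reads alike on the two cores: the same change on two cores in this assay, a number 0.8 percentage points higher (within the scatter) from compound 1 to compound 2 and a number 0.4 percentage points lower (within the scatter) from compound 3 to compound 4, 1.2 percentage points apart, within the scatter of two such steps

So, in these two pairs, going from 4-bromophenyl to 4-methoxyphenyl produced no step beyond the scatter on either core, but two pairs at a single dose do not show that this holds on any other core in the series.

The compounds shown leave open whether an amine, a carboxylic acid or a longer chain on that aromatic carbon would also leave the read-out unmoved. They also leave open which of the differences between the core of compound 1 and the core of compound 3 accounts for the gap between those compounds.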